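The source may hold more compounds than are shown below. What is called first, only, known or untested is meant among the compounds shown, and "the series" means these compounds.

Measured compounds:
compound 1 `Clc1cccc(Cl)c1Cc1nnc(Nc2ccc(COCc3cccnc3)cc2)o1` gives 81000 nM in an ADME assay on MT2 cells (Homo sapiens) for cytotoxicity, read by MTT assay; on this read-out higher numbers stand for lower toxicity in this test and lower numbers for higher toxicity in this test.
compound 2 `Clc1cccc(Cl)c1Cc1nnc(Nc2ccc(COCc3ccccn3)cc2)o1` gives only a limit of the assay, > 100000 nM, in this assay.
compound 3 `COCc1ccc(Nc2nnc(Cc3c(Cl)cccc3Cl)o2)cc1` gives 100000 nM in this assay.

Among the two numbers, compound 3 stands highest, and its nearest neighbour is compound 1, with a 1.2-fold higher number from compound 1 to compound 3 (0.09 log units; within the scatter). The value of compound 2 is a limit (the limit of > 100000 nM in this assay, at which 1 of the 3 values shown sits), so the step of a number no higher from compound 2 to compound 3 (the limit leaves the size open) has no readable size. Compound 4 `Clc1cccc(Cl)c1Cc1nnc(Nc2ccc(COCc3ccco3)cc2)o1` differs from compound 3 by furan-2-yl in place of hydrogen on a saturated chain carbon bound to an oxygen on a saturated carbon. Within the data shown here, the steps that bear on this change, a group leaving or entering the same place, are a 1.2-fold higher number from compound 1 to compound 3 (0.09 log units; within the scatter) and a number no higher from compound 2 to compound 3 (the limit leaves the size open); the first lies within the scatter and the second cannot be sized. For compound 4 no step beyond the scatter is therefore expected in this assay, and the expected change a 1.1-fold lower number from compound 3 to compound 4 (0.05 log units; within the scatter) is small. Compound 4 is estimated at 90000 nM, between 45000 nM and 180000 nM.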

Compound 4, half-maximal cytotoxic concentration: 12000 nM
Beside the measured number, compound 4's estimate is 7.5-fold (0.88 log units) above it; the whole stated range lies above it.
By their numbers in this assay, from the lowest: compound 4; then compounds 1 and 3 (each within the scatter of the next).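

In this assay, among these compounds, the place on a saturated chain carbon bound to an oxygen on a saturated carbon turns out to respond to what it carries: furan-2-yl gives an 8.3-fold lower number from compound 3 to compound 4 (0.92 log units; beyond the scatter), whereas the earlier steps there lay within the scatter or could not be sized. Replacing either pyridinyl group with furan-2-yl also lowers the number, with a 6.8-fold lower number from compound 1 to compound 4 (0.83 log units; beyond the scatter) and an at least 8.3-fold lower number from compound 2 to compound 4 (0.92 log units; beyond the scatter). The second of these steps rests on a limit of the assay: the limit of > 100000 nM in this assay, at which 1 of the 4 values shown sits. The compounds shown leave open whether a thiophen-2-yl group, a phenyl ring or a tertiary amine at this place would give a similarly low number.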